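Trifluoromethyl for bromo on the pendant phenyl ring

The source may report more compounds than this note shows. Statements on the series, on what has been measured and on what is new or still open speak of the compounds shown alone.

Compound 1 `CC1(C)CC(=O)C2=C(C1)N(c1ccccc1)C(c1ccc(Br)cc1)N(c1ccccc1)C2` and compound 2 `CC1(C)CC(=O)C2=C(C1)N(c1ccccc1)C(c1cccc(Br)c1)N(c1ccccc1)C2` share one core and differ only in the pendant phenyl ring. In an ADME assay on BHK-21 cells (Mesocricetus auratus) for cytotoxicity, read by MTT assay, with a stated time of 48 h (on this read-out lower numbers stand for higher toxicity in this test and higher numbers for lower toxicity in this test), compound 1 gives > 20000 nM, which is a limit of the assay and not a number. In this assay compound 2 gives > 20000 nM, again a limit rather than a number. The step that the two limits leave unreadable from compound 1 to compound 2 accordingly cannot be read. Compound 2 stands at the limit, and both values shown sit there (the limit of > 20000 nM in this assay, at which 2 of the 2 values shown sit).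

Compound 3 `CC1(C)CC(=O)C2=C(C1)N(c1ccccc1)C(c1cccc(C(F)(F)F)c1)N(c1ccccc1)C2` differs from compound 2 in trifluoromethyl in place of bromo on an aromatic carbon, a change from 3-bromophenyl to 3-(trifluoromethyl)phenyl. No measured step bears directly on this change; the only step shown, a step that the two limits leave unreadable from compound 1 to compound 2, gives no size. With both known values at the limit (the limit of > 20000 nM in this assay, at which 2 of the 2 values shown sit), compound 3 is expected to sit at or beyond that limit as well, and the step that the limit leaves unreadable from compound 2 to compound 3 is expected to stay within the scatter. Compound 3 is estimated at 30000 nM, with a range from 10000 nM to 100000 nM, and a reading given only as a limit is the most likely outcome.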

Compound 3, half-maximal cytotoxic concentration: 17900 nM
Beside the measured number, compound 3's estimate is 1.7-fold (0.22 log units) above it, and the stated range covers the measured number.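

Compound 3 gives the series its first reading in this assay that is a number rather than a limit, so trifluoromethyl at this place on the pendant phenyl ring provides a value against which later changes can be sized. Trifluoromethyl in place of bromo gives an at least 1.1-fold lower number from compound 2 to compound 3 (0.04 log units; that floor lies within the scatter), and the change from 4-bromophenyl to 3-(trifluoromethyl)phenyl gives an at least 1.1-fold lower number from compound 1 to compound 3 (0.04 log units; that floor lies within the scatter). Neither floor shows a real separation between the compounds, and the true size of both steps remains unreadable, because the other two values are limits: the limit of > 20000 nM in this assay, at which 2 of the 3 values shown sit.

The compounds shown leave open whether any substituent on the pendant phenyl ring moves the reading clearly away from the limit, for example an amine or a carboxylic acid in place of bromo or trifluoromethyl. They also leave open whether trifluoromethyl would read the same at another place on that ring, since only one trifluoromethyl compound is shown and its bromo counterparts give no number to compare with.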